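From cycloheptyl to an ester side chain

A few compounds are considered here, and "the series" means these few. Any claim that something is new, unique, unknown or untested is made for them only; others in the source may bear on it.

Measured in an ADME assay on HOS cells (Homo sapiens) for cytotoxicity, read by a luciferase reporter and ATP content; on this read-out higher numbers stand for lower toxicity in this test and lower numbers for higher toxicity in this test:
compound 1 `O=C(NCc1ccc(F)cc1F)c1c(NC2CCCCCC2)c2cccnc2n(O)c1=O`: 68000 nM
compound 2 `O=C(NCc1ccc(F)cc1F)c1c(NCCCCc2ccccc2)c2cccnc2n(O)c1=O`: 102000 nM

Among the measured compounds shown here, compound 1 stands level with compound 2, the only other measured compound, as their two numbers lie within the scatter. Compound 3 `COC(=O)CNc1c(C(=O)NCc2ccc(F)cc2F)c(=O)n(O)c2ncccc12` has not yet been measured. Its change from compound 1 is (methoxycarbonyl)methyl in place of cycloheptyl on a nitrogen on an aromatic ring. For the measured compounds named here, one measured step bears on this: a 1.5-fold higher number from compound 1 to compound 2 (0.18 log units; within the scatter), which also replaced cycloheptyl on a nitrogen on an aromatic ring. On that single step, no change beyond the scatter is expected in this assay. The estimated step is a 1.5-fold higher number from compound 1 to compound 3 (0.17 log units; within the scatter). For compound 3 the expected value is 100000 nM, with an estimated range of 40000 nM to 250000 nM.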

Compound 3, half-maximal cytotoxic concentration: > 250000 nM
Compound 3 ended at the assay's limit; the forecaster's own chance of this, stated with the estimate: 25%; middle value at least 2.5-fold (0.39 log units) away from the limit.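

In this assay, the group on a nitrogen on an aromatic ring proves able to shift the number beyond the scatter, which compounds 1 and 2 alone did not show: the change gives an at least 3.6-fold higher number from compound 1 to compound 3 (0.56 log units; beyond the scatter) and an at least 2.4-fold higher number from compound 2 to compound 3 (0.38 log units; beyond the scatter). Compound 3 gives > 250000 nM, which is a limit of the assay and not a number: the limit of > 250000 nM in this assay, at which 1 of the 3 values shown sits.

The compounds shown leave open whether the higher number goes with the ester or simply with a short open chain. A carboxylic acid or a plain propyl chain in the same place would separate the two.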